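A Ring-Bearing Group Returns to the Amine Nitrogen

A few compounds are considered here, and "the series" means these few. Any claim that something is new, unique, unknown or untested is made for them only; others in the source may bear on it.

Within the data shown here, in a functional assay on HeLa cells (Homo sapiens) for inhibition, read by MTT assay, with a stated time of 48 h (a higher number here means a weaker inhibitor, a lower number a stronger inhibitor), compound 2 `CCOC(=O)C1=C(N/N=C(/Cl)C#N)Nc2[nH]nc(C)c2C1c1ccc(N(C)C)cc1` gives 26200 nM, the lower of the two numbers measured so far, while compound 1 `CCOC(=O)C1=C(N/N=C(/C(=O)Br)c2ccc(Br)cc2)Nc2[nH]nc(C)c2C1c1ccc(N(C)C)cc1` gives 68500 nM. The unmeasured compound 3 `CCOC(=O)C1=C(N/C=N/c2ccc([N+](=O)[O-])cc2)Nc2[nH]nc(C)c2C1c1ccc(N(C)C)cc1` keeps the shared core and differs from compound 2 in one place: a group of 11 heavy atoms (7 carbon, 2 nitrogen, 2 oxygen; one six-membered aromatic ring of carbon only) in place of a group of 5 heavy atoms (2 carbon, 2 nitrogen, 1 chlorine; no ring), on an amine nitrogen. A group with one six-membered aromatic ring of carbon only thus replaces a group with no ring, on an amine nitrogen. Among the measured compounds shown here, one measured step bears on this change: a 2.6-fold lower number from compound 1 to compound 2 (0.42 log units; beyond the scatter). It is modest but beyond the scatter, and it came with the loss of a different ring-bearing group, so it is only a rough guide. Read backwards, that step suggests a higher number. In this assay a modest rise of similar size is therefore expected, an estimated 2.3-fold higher number from compound 2 to compound 3 (0.36 log units; beyond the scatter). Compound 3 is estimated at 60000 nM, with an expected range of 20000 nM to 150000 nM.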

Compound 3, half-maximal inhibitory concentration: 57800 nM
Estimate against measurement, compound 3: 1.0-fold (0.02 log units) above, and the stated range covers the measured number.
By their numbers in this assay, from the lowest: compound 2; then compounds 3 and 1 (each within the scatter of the next).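

In this assay, the amine nitrogen now has a direct comparison of a group with one six-membered aromatic ring of carbon only against a group with no ring: a 2.2-fold higher number from compound 2 to compound 3 (0.34 log units; beyond the scatter). The two ring-bearing groups on this nitrogen cannot be told apart, with a 1.2-fold lower number from compound 1 to compound 3 (0.07 log units; within the scatter), so among these three compounds only compound 2, with the ringless group, stands apart, at the lowest number. No measurement available here speaks to what lies behind this difference.

The compounds shown leave open whether the ring itself or other parts of these groups set the numbers, since each group differs in more than its ring. Going by these compounds, how a short alkyl chain or a carboxylic acid on this nitrogen would compare with compound 2 also remains open.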